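Methylsulfonyl for cinnamoyl on the ring nitrogen

This account rests on a few compounds, and the source may have more. Where it says the series, first, only, none or still open, it means among the compounds named here.

Measured so far:
compound 1 `CC(=O)N1N=C(c2ccc(N3CCN(C)CC3)cc2)CC1c1ccc(N(C)C)cc1`: -1%
compound 2 `CN1CCN(c2ccc(C3=NN(C(=O)/C=C/c4ccccc4)C(c4ccc(N(C)C)cc4)C3)cc2)CC1`: 35.9%

In a functional assay on MDA-MB-231 cells (Homo sapiens) for inhibition, read by sulforhodamine B assay, tested at 10 uM (on this read-out higher numbers stand for more inhibition at the one concentration tested (going by the name of the read-out) and lower numbers for less inhibition), compound 2 gives the higher of the two numbers; compound 1 sits well under it, and the step of a number 36.9 percentage points higher from compound 1 to compound 2 (beyond the scatter) is beyond the scatter. Compound 3 `CN1CCN(c2ccc(C3=NN(S(C)(=O)=O)C(c4ccc(N(C)C)cc4)C3)cc2)CC1` carries methylsulfonyl in place of (2-phenylethenyl)carbonyl on an amine nitrogen in a ring. Among the compounds with values here, the only step on record bears on it indirectly: compound 1 and compound 2 show that the group on this ring nitrogen matters, a large aromatic-bearing group raising inhibition well beyond the scatter over a methyl on the carbonyl carbon. Within the data shown here, compound 3 goes the other way, back to a small group on that nitrogen, so a drop of roughly the size seen between compound 1 and compound 2 is expected, with the uncertainty that methylsulfonyl itself has no measured example here. For compound 3 the expected change is a number 30.9 percentage points lower from compound 2 to compound 3 (beyond the scatter). Compound 3 is therefore estimated at 5%, within -10% to 25%.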

Compound 3, a percentage reported as inhibition, at one concentration (the size of the read-out at that concentration, not a potency): 0.6%
The estimate for compound 3 lay 4.4 percentage points above the measured number; the measured number falls inside the stated range.
By their numbers in this assay, from the lowest: compounds 1 and 3 (each within the scatter of the next); then compound 2.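

In this assay, methylsulfonyl in place of (2-phenylethenyl)carbonyl on the ring nitrogen gives a number 35.3 percentage points lower from compound 2 to compound 3 (beyond the scatter) and so removes the advantage that compound 2 held over the acetyl compound. Methylsulfonyl in place of acetyl gives a number 1.6 percentage points higher from compound 1 to compound 3 (within the scatter) and so offers no separation between these two small groups, which leaves compound 2 as the only one of the three standing apart on this read-out.

As far as these compounds go, whether the phenyl ring, the double bond or the carbonyl link carries the higher inhibition of compound 2 remains open. A benzenesulfonyl group on this nitrogen would test whether the sulfonyl link can hold a phenyl ring as well, and a benzoyl or 3-phenylpropanoyl group would separate the ring from the double bond. No measurement at hand explains these steps.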